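Swapping a Side Group on a Serotonin Receptor Agonist

The source may report more compounds than this note shows. Statements on the series, on what has been measured and on what is new or still open speak of the compounds shown alone.

Measured compounds:
Compound 1 `O[C@@H]1Cc2ccccc2[C@H]1NC1CCN(CCCc2c[nH]c3ccc(-n4cnnc4)cc23)CC1` — 75%
Compound 2 `CN(Cc1ccccc1)CC1CCN(CCCc2c[nH]c3ccc(-n4cnnc4)cc23)CC1` — 93%

In a functional assay on CHO cells for activation of 5-hydroxytryptamine receptor 1D (Homo sapiens), read by GTPgammaS binding (a lower number here means a smaller maximal response, a higher number a larger maximal response), compound 2 reaches the larger maximal response of the two: its step of a number 18 percentage points higher from compound 1 to compound 2 (beyond the scatter) puts it beyond the scatter above compound 1. Compound 3 `CC(CO)(NC1CCN(CCCc2c[nH]c3ccc(-n4cnnc4)cc23)CC1)c1ccccc1` differs from compound 2 by (1-(hydroxymethyl)-1-phenylethyl)amino in place of (benzyl(methyl)amino)methyl on a saturated ring carbon. Among the measured compounds shown here, only one measured step exists, a number 18 percentage points higher from compound 1 to compound 2 (beyond the scatter), and it touches the same saturated ring carbon; there the group that carries a hydroxyl and is joined to the ring through an amino nitrogen, as in compound 1, gave the smaller maximal response. Compound 3 brings back both features, though not the same group, so a moderate drop below compound 2 is expected, of roughly a number 11 percentage points lower from compound 2 to compound 3 (beyond the scatter). For compound 3 the expected value in this assay is therefore 82%, with a range from 65% to 100%.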

Compound 3, largest response reached (reported as efficacy), in percent of the reference or control that the assay uses: 59%
The estimate for compound 3 lay 23 percentage points above the measured number; the whole stated range lies above it.
By their numbers in this assay, from the lowest: compound 3; then compound 1; then compound 2.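

On this saturated ring carbon, in this assay, putting (1-(hydroxymethyl)-1-phenylethyl)amino in place of (benzyl(methyl)amino)methyl gives a large change: a number 34 percentage points lower from compound 2 to compound 3 (beyond the scatter) and the lowest of the three maximal responses. Compound 1 and compound 3 both hold a hydroxyl and both join the ring through an amine nitrogen, yet the group on that nitrogen still matters, with 1-(hydroxymethyl)-1-phenylethyl in place of 2-hydroxy-2,3-dihydro-1H-inden-1-yl giving a number 16 percentage points lower from compound 1 to compound 3 (beyond the scatter) in a modest step, so those two shared features do not set the response alone. No measurement available here explains either difference.

Going by these compounds, the step from compound 2 changes the linking atoms and adds the hydroxyl at once, so their separate contributions remain open. A 1-methyl-1-phenylethyl group on the same amine nitrogen, without the hydroxyl, would help to tell them apart.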